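Methyl on the Benzyl Ring: From Compound 2 to Compound 3

The source may hold more compounds than are shown below. What is called first, only, known or untested is meant among the compounds shown, and "the series" means these compounds.

Measured compounds in a functional assay on A2780 cells (Homo sapiens) for cytotoxicity, read by MTT assay, with a stated time of 48 h; on this read-out higher numbers stand for weaker inhibition and lower numbers for stronger inhibition:
compound 1 `CN(C)CCCCCCN(C)C1=Nc2ccccc2C(CC(=O)NCc2ccccc2)N1c1ccc(-c2ccccc2)cc1`, which gives 1190 nM
compound 2 `CN(C)CCN1CCN(C2=Nc3ccccc3C(CC(=O)NCc3ccccc3)N2c2ccc(-c3ccccc3)cc2)CC1`, which gives 1390 nM

Compound 2 holds the highest of the two numbers, and its nearest neighbour is compound 1, separated by a 1.2-fold higher number from compound 1 to compound 2 (0.07 log units; within the scatter). That single step swaps the group on the carbon with a double bond to nitrogen and leaves the rest of the shared core untouched.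

Compound 3 `Cc1ccc(CNC(=O)CC2c3ccccc3N=C(N3CCN(CCN(C)C)CC3)N2c2ccc(-c3ccccc3)cc2)cc1` differs from compound 2 at a different place: methyl in place of hydrogen on an aromatic carbon, the difference reading at one bond further out as benzyl to 4-methylbenzyl. Among the measured compounds shown here, no measured step touches this ring, so nothing in the data speaks directly to the change. For the measured compounds named here, the one step available shows that a far larger alteration elsewhere stayed within the scatter, which offers no ground to expect a move beyond the scatter here either. Compound 3 is therefore expected to sit close to compound 2, a step of about a 1.0-fold higher number from compound 2 to compound 3 (0.00 log units; within the scatter), and its estimated value in this assay is 1400 nM with a range from 700 nM to 2800 nM.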

Compound 3, half-maximal inhibitory concentration: 1600 nM
The estimate for compound 3 lay 1.1-fold (0.06 log units) below the measured number, and the stated range covers the measured number.
By their numbers in this assay, from the lowest: compounds 1, 2 and 3 (each within the scatter of the next).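

The step to 4-methylbenzyl is the first among these compounds to touch the benzyl group on the amide, and in this assay it reads as a 1.2-fold higher number from compound 2 to compound 3 (0.06 log units; within the scatter). On this aromatic carbon, para to a large group, methyl in place of hydrogen therefore leaves compound 2 and compound 3 indistinguishable, so the benzyl end now joins the side chain, where the earlier change gave a 1.2-fold higher number from compound 1 to compound 2 (0.07 log units; within the scatter), as a second place where a single change stayed within the scatter. No available evidence bears on this result, and the step by itself gives no explanation for it.

As far as these compounds go, a single methyl says little about the position as a whole, and it remains open whether a methoxy group, a carboxylic acid or an aminomethyl group at the same carbon would move the number beyond the scatter. From the compounds shown here alone, it also remains open whether the 4-methylbenzyl group would read the same way when paired with the (6-(dimethylamino)hexyl)(methyl)amino side chain of compound 1.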